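Acetylation of the Hydroxyethyl Side Chain of Compound 1

The source may report more compounds than this note shows. Statements on the series, on what has been measured and on what is new or still open speak of the compounds shown alone.

Measured compounds:
- compound 1 `O=C1c2ccccc2NS(=O)(=O)N1COCCO`: 160 ug/mL
- compound 2 `CCCOCN1c2ccccc2C(=O)NS1(=O)=O`: > 50 ug/mL

Among the measured compounds shown here, compound 1 is the only compound in this set with a numerical read-out. In a functional assay on HEL cells (Homo sapiens) (on this read-out lower numbers stand for higher toxicity in this test and higher numbers for lower toxicity in this test), compound 1 gives 160 ug/mL. Compound 2 gives only > 50 ug/mL, which is a limit of the assay and not a number. Compound 2 thus sits at the limit of > 50 ug/mL in this assay, at which 1 of the 2 values shown sits. For the measured compounds named here, no step between two measured compounds can be computed here, so no measured step guides the expectation for the new compound.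

Compound 3 `CC(=O)OCCOCN1C(=O)c2ccccc2NS1(=O)=O` differs from compound 1 by a single change: acetyl in place of hydrogen on an oxygen on a saturated carbon. Read one bond further out, the change turns a hydroxy group into an acetoxy group.

Nothing measured in this set speaks to the effect of such a change on cytotoxicity. The step from compound 1 to compound 3 is therefore expected to be small, a 1.2-fold lower number from compound 1 to compound 3 (0.09 log units; within the scatter), no larger than the usual scatter. Compound 3 is accordingly expected to give about 130 ug/mL, within a range from 55 ug/mL to 300 ug/mL.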

Compound 3, half-maximal cytotoxic concentration: > 200 ug/mL
Compound 3: only a limit was reported (the forecaster's own chance of this, stated with the estimate: 35%); middle value at least 1.5-fold (0.18 log units) from the limit.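

Compound 3 carries its reading in this assay only as a limit of the assay and not as a number: the limit of > 200 ug/mL in this assay, at which 1 of the 3 values shown sits. The step is an at least 1.2-fold higher number from compound 1 to compound 3 (0.09 log units; that floor lies within the scatter), so acetyl in place of hydrogen on this oxygen does not bring the number down, although the floor of the step does not establish a real rise. Among the compounds shown here, this is the first measured step at this position, and it shows that the free hydroxy group of the 2-hydroxyethyl end is not needed to keep the toxicity in this test low, since the 2-acetoxyethyl end stays on the low-toxicity side of the read-out.

From the compounds shown here alone, how far the true value of compound 3 lies beyond its limit stays open, and with it whether the change has any real effect on the read-out or none. Also open is whether this tolerance extends to other ends at the same oxygen, such as a longer acyl chain, a carboxylic acid or an amine, since the compounds shown speak only to acetyl in place of hydrogen.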